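Chloro for Bromo on the Five-Membered Aromatic Ring

The source may report more compounds than this note shows. Statements on the series, on what has been measured and on what is new or still open speak of the compounds shown alone.

Three compounds sharing one core were tested in a functional assay on KB cells (Homo sapiens) for cytotoxicity, read by spectrophotometry and crystal violet staining; a higher number here means a weaker inhibitor, a lower number a stronger inhibitor. Compound 1 `COC(=N)c1c(Cl)n(C2O[C@H](CO)[C@@H](O)[C@H]2O)c2cc(Cl)c(Cl)cc12` gives 50000 nM, and compound 2 `CO/N=C/c1c(Cl)n(C2O[C@H](CO)[C@@H](O)[C@H]2O)c2cc(Cl)c(Cl)cc12` gives 70000 nM; the step of a 1.4-fold higher number from compound 1 to compound 2 (0.15 log units; within the scatter) exchanges one group of 4 heavy atoms for another on an aromatic carbon. Compound 3 `N/C(=N\O)c1c(Br)n(C2O[C@H](CO)[C@@H](O)[C@H]2O)c2cc(Cl)c(Cl)cc12` gives 35000 nM, the lowest of the three numbers, yet its gap to compound 1 and to compound 2 stays within the scatter, so no order among the three can be claimed.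

Compound 4 `N/C(=N\O)c1c(Cl)n(C2O[C@H](CO)[C@@H](O)[C@H]2O)c2cc(Cl)c(Cl)cc12` differs from compound 3 by chloro in place of bromo on an aromatic carbon, on an aromatic carbon of a five-membered aromatic ring with 1 nitrogen, next to the ring nitrogen. Among the measured compounds shown here, no measured step exchanges bromo for chloro; the only step available, a 1.4-fold higher number from compound 1 to compound 2 (0.15 log units; within the scatter), sits elsewhere on the core and lies within the scatter. With nothing bearing on this exchange, a change within the scatter is expected. Compound 4 is therefore expected to give 35000 nM, between 17000 nM and 70000 nM. The implied step no change at the digits printed from compound 3 to compound 4 (within the scatter) is expected to stay within the scatter.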

Compound 4, half-maximal inhibitory concentration: > 100000 nM
Compound 4: a limit, no number; the forecaster's own chance of this, stated with the estimate: 10%; middle value at least 2.8-fold (0.45 log units) from the limit.
By their numbers in this assay, from the lowest: compounds 3, 1 and 2 (each within the scatter of the next). At a limit, above all of these: compound 4.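

In this assay, chloro in place of bromo on this aromatic carbon, next to the ring nitrogen, gives an at least 2.8-fold higher number from compound 3 to compound 4 (0.45 log units; beyond the scatter), a step at least modest in size. Compound 4 gives > 100000 nM, which is a limit of the assay and not a number. Exchanging one group of 4 heavy atoms for another on an aromatic carbon gives an at least 1.4-fold higher number from compound 2 to compound 4 (0.15 log units; that floor lies within the scatter) and an at least 2.0-fold higher number from compound 1 to compound 4 (0.30 log units; that floor lies within the scatter); the floors of both steps lie within the scatter, so neither step shows a change that can be claimed. The exchange of chloro for bromo is bounded on one side only: the limit of > 100000 nM in this assay, at which 1 of the 4 values shown sits.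

Going by these compounds, how fluoro, iodo or a methyl group would fare at this position remains open. So does whether bromo in place of chloro would shift the numbers of compound 1 and compound 2 in the same way, as the exchange is seen only once, with the other groups on the shared core held fixed.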